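The source may hold more compounds than are shown below. What is called first, only, known or untested is meant among the compounds shown, and "the series" means these compounds.

Working notes on a small series read in a functional assay on HeLa cells (Homo sapiens) for antiproliferative activity, read by MTT assay, with a stated time of 72 h; on this read-out lower numbers stand for stronger inhibition and higher numbers for weaker inhibition. Compound 1 `COc1ccc(-n2ccnc2-c2cc(OC)c(OC)c(OC)c2)cc1[N+](=O)[O-]` gives 2500 nM, compound 2 `COc1cc(OC)cc(-n2ccnc2-c2cc(OC)c(OC)c(OC)c2)c1` gives 41400 nM, and compound 3 `COc1ccc(C(=O)Nc2cc(OC)c(OC)c(OC)c2)cc1[N+](=O)[O-]` gives 3700 nM. Compound 3 thus stands within the scatter of compound 1, while compound 2 carries a higher number than either, by a gap beyond the scatter.

The next compound is compound 4 `COc1ccc(C(=O)Nc2cc(OC)c(OC)c(OC)c2)cc1N`. It differs from compound 3 in one place, with amino in place of nitro on an aromatic carbon, ortho to a methoxy group and meta to a large group (amino in place of nitro on an aromatic carbon). Among the measured compounds shown here, no measured pair isolates this exchange, and no compound with the amino group has a reading yet, so the direction is a judgement and not a trend. The nitro group is present in compound 1 and in compound 3, and it is absent from compound 2, but compound 2 also differs from them elsewhere, so this comparison does not settle the question.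

A moderate move towards stronger inhibition is expected, stated as the estimated 3.1-fold lower number from compound 3 to compound 4 (0.49 log units; beyond the scatter), and a result within the scatter would not be surprising. For compound 4 the estimate is 1200 nM, with an expected range of 200 nM to 7000 nM.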

Compound 4, half-maximal inhibitory concentration: > 100000 nM
Compound 4: only a limit was reported (the forecaster's own chance of this, stated with the estimate: 3%); at least 83-fold (1.92 log units) between middle value and limit.
By their numbers in this assay, from the lowest: compounds 1 and 3 (each within the scatter of the next); then compound 2. At a limit, above all of these: compound 4.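

In this assay, among the compounds shown here, the exchange of nitro for amino on an aromatic carbon, ortho to a methoxy group and meta to a large group, gives an at least 27-fold higher number from compound 3 to compound 4 (1.43 log units; beyond the scatter), and this large step is the first that isolates a change in one place. Compound 4 has only a limit of the assay and not a number, and it is the only compound shown that sits at this limit: the limit of > 100000 nM in this assay, at which 1 of the 4 values shown sits. From the compounds shown here alone, the step shows that the reading is highly sensitive to which of these two groups occupies this position, although this holds only for the core of compound 3 and compound 4, and the true size of the step remains unknown.

Going by these compounds, what stays open is whether the step belongs to the amino group itself or to the departure of nitro; a hydroxyl, a methyl or an acetamide at this place, or plain hydrogen, would separate the two. On these data alone, it is also open whether the same exchange on the core of compound 1 would give a step of similar size.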